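Swapping a Furan for an Indole on a Lactam Core

The compounds below may be only part of what the source reports. "The series", "measured", "known", "first", "only" and "open" are said of these compounds alone.

The compounds here share one core, and their worth is judged in a physicochemical assay for solubility, read by spectrophotometry, in phosphate buffer, with a stated time of 2 h, at pH 7.4; a higher number here means a more soluble compound, a lower number a less soluble compound. Compound 1 `COc1ccc2[nH]c(C(=O)N3CC(=O)N(Cc4ccccc4)[C@@H](CN4CCCC4)C3)cc2c1` gives only a limit of the assay in this assay, recorded as > 25000 nM. Going by the values given here, compound 2 `COc1ccc2[nH]c(C(=O)N3CC(=O)N(Cc4ccoc4)[C@@H](Cc4ccccc4)C3)cc2c1` gives a measured number in this assay, 63600 nM, which is the only real number among the two values shown; the other sits at the limit of > 25000 nM in this assay, at which 1 of the 2 values shown sits.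

Compound 3 `COc1ccc2[nH]c(C(=O)N3CC(=O)N(Cc4c[nH]c5ccccc45)[C@@H](Cc4ccccc4)C3)cc2c1` is not yet measured. It differs from compound 2 in one place: 1H-indol-3-yl in place of furan-3-yl on a saturated chain carbon bound to an amide-type nitrogen in a ring. No step between two measured compounds is shown, so there is nothing to calibrate against. Still, a move from a small five-membered aromatic group to a fused two-ring aromatic group is expected here to lower solubility in this assay by more than the usual scatter, with the step from compound 2 to compound 3 estimated as a 3.2-fold lower number from compound 2 to compound 3 (0.50 log units; beyond the scatter). Compound 3 is therefore expected to give about 20000 nM in this assay, within a range of 6000 nM to 60000 nM.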

Compound 3, solubility: 10300 nM
Beside the measured number, compound 3's estimate is 1.9-fold (0.29 log units) above it; the measured number falls inside the stated range.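

Going by these compounds alone, this is the first step between two measured compounds on the shared core, and it puts a size on a change at this position. In this assay, putting 1H-indol-3-yl in place of furan-3-yl on a saturated chain carbon bound to an amide-type nitrogen in a ring gives a 6.2-fold lower number from compound 2 to compound 3 (0.79 log units; beyond the scatter), so for this pair the group at this position does make a difference to the read-out. The change takes the group from 5 to 9 heavy atoms, adds a six-membered aromatic ring of carbon only, and trades a hydrogen-bond acceptor for a hydrogen-bond donor, so several features move together and this one step cannot pull them apart.

Nothing measured here gives a reason for the size of this step. Going by these compounds, it remains open how benzofuran-3-yl, which keeps the fused two-ring shape with an oxygen in place of the indole nitrogen, or 1-methyl-1H-indol-3-yl, which carries a methyl group on that nitrogen, would compare with compound 2 and compound 3 at this position.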